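The source may hold more compounds than are shown below. What is called first, only, known or untested is meant among the compounds shown, and "the series" means these compounds.

Compound 1, `NC(=O)c1cn(Cc2nnc(-c3cc(S(N)(=O)=O)c(SCc4ccccc4)cc3Cl)o2)nn1`: 75000 nM
Compound 2, `NS(=O)(=O)c1cc(-c2nnc(Cn3cc(-c4ccccc4)nn3)o2)c(Cl)cc1SCc1ccccc1`: 7000 nM

Among the measured compounds shown here, of the two numbers measured in a functional assay on HeLa cells (Homo sapiens) for cytotoxicity, read by MTT assay, with a stated time of 72 h (on this read-out lower numbers stand for stronger inhibition and higher numbers for weaker inhibition), compound 2 gives the lower one, and the single step seen so far, an 11-fold lower number from compound 1 to compound 2 (1.03 log units; beyond the scatter), separates the two compounds. Compound 3, `COc1ccc(-c2cn(Cc3nnc(-c4cc(S(N)(=O)=O)c(SCc5ccccc5)cc4Cl)o3)nn2)cc1`, differs from compound 2 by methoxy in place of hydrogen on an aromatic carbon. For the measured compounds named here, no measured step swaps a phenyl for a 4-methoxyphenyl, so nothing measured bears directly on this change, and the step is expected to stay within the scatter: no change at the digits printed from compound 2 to compound 3 (within the scatter). Compound 3 is therefore estimated at 7000 nM, expected to fall between 2500 nM and 20000 nM.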

Compound 3, half-maximal inhibitory concentration: 68000 nM
Compound 3: the middle estimate sits 9.7-fold (0.99 log units) below what was measured; measured number above the stated range.
By their numbers in this assay, from the lowest: compound 2; then compounds 3 and 1 (each within the scatter of the next).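

In this assay, the carbon para to a large group on the phenyl proves sensitive to a small addition: methoxy in place of hydrogen gives a 9.7-fold higher number from compound 2 to compound 3 (0.99 log units; beyond the scatter). An aromatic ring at this place is thus not enough on its own, as 4-methoxyphenyl in place of carbamoyl gives only a 1.1-fold lower number from compound 1 to compound 3 (0.04 log units; within the scatter). No available evidence explains this change. Going by these compounds, whether a fluorine, a hydroxy or an amine on this same carbon would read like hydrogen or like methoxy stays open, and so does the effect of a longer chain such as ethoxy.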